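The source may report more compounds than this note shows. Statements on the series, on what has been measured and on what is new or still open speak of the compounds shown alone.

Measured so far, in a functional assay on the whole organism for inhibition, with Chenopodium ficifolium as the target, with a stated time of 72 h, tested at 100 mg/L; a higher number here means more inhibition of growth at the concentration tested, a lower number less inhibition of growth:

- Compound 1 `COc1cc(C)nc2n/c(=N/C(=O)c3c(-c4ccc(Cl)cc4Cl)noc3C)sn12` gives 80.4%.
- Compound 2 `Cc1onc(-c2ccc(Cl)cc2Cl)c1C(=O)/N=c1/nc2nc(Cl)cc(C)n2s1` gives 73.6%.
- Compound 3 `COc1cc(OC)n2s/c(=N\C(=O)c3c(-c4ccc(Cl)cc4Cl)noc3C)nc2n1` gives 82.7%.

Compound 3 has the highest of the three numbers, but its gaps to compound 1 and to compound 2 both lie within the scatter of this assay, so the three cannot be ranked.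

Compound 4 `COc1cc(Cl)nc2n/c(=N/C(=O)c3c(-c4ccc(Cl)cc4Cl)noc3C)sn12` differs from compound 3 in one place: chloro in place of methoxy on an aromatic carbon.

For the measured compounds named here, only one measured step changes a single group at that position: the exchange of methyl for methoxy from compound 1 to compound 3, which gave a number 2.3 percentage points higher from compound 1 to compound 3 (within the scatter). Going by the values given here, no measured pair shows chloro replacing methoxy there, so the change itself has no direct precedent; compound 2, which carries a chloro group in its core, shows a value of the same order as the others.

Compound 4 is therefore expected to stay in the same range, with an estimated step of a number 5.7 percentage points lower from compound 3 to compound 4 (within the scatter).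

The estimate for compound 4 is 77%, within 64% to 88%.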

Compound 4, percent growth inhibition at one concentration: 65.9%
Compound 4: middle estimate off by 11.1 percentage points, on the high side; the range from low to high includes it.
By their numbers in this assay, from the lowest: compounds 4, 2, 1 and 3 (each within the scatter of the next, the first and the last beyond it).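

In this assay, for the compounds shown here, this position now shows a step beyond the scatter, which the earlier compounds did not: chloro in place of methoxy gives a number 16.8 percentage points lower from compound 3 to compound 4 (beyond the scatter), and chloro in place of methyl gives a number 14.5 percentage points lower from compound 1 to compound 4 (beyond the scatter). Among the three groups seen here, chloro therefore stands apart from methoxy, while methyl and methoxy remain within the scatter of each other. Methoxy in place of methyl gives a number 7.7 percentage points lower from compound 2 to compound 4 (within the scatter), so that change stays small when chloro is present, and it reads alike on both cores: the same change on two cores in this assay, a number 2.3 percentage points higher (within the scatter) from compound 1 to compound 3 and a number 7.7 percentage points lower (within the scatter) from compound 2 to compound 4, 10 percentage points apart, within the scatter of two such steps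

The compounds shown leave open how an amine or a longer chain such as ethoxy would behave at this position. They also leave open whether chloro would give a step of similar size with a group other than methoxy beside it in the shared core.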